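A few compounds are considered here, and "the series" means these few. Any claim that something is new, unique, unknown or untested is made for them only; others in the source may bear on it.

Measured in an ADME assay on the whole organism (Rattus norvegicus, strain Sprague-Dawley) for pharmacokinetics, read by LC-MS, at a dose of 5 mg/kg by the oral route; on this read-out higher numbers stand for higher oral bioavailability and lower numbers for lower oral bioavailability:
- compound 1 `Cc1nc(C)c([C@H](OC(C)(C)C)C(=O)O)c(N2CCC(C)(C)CC2)c1-c1ccc2c(c1)CCN(Cc1cccc(F)c1C)C2`: 64%
- compound 2 `Cc1nc(C)c([C@H](OC(C)(C)C)C(=O)O)c(N2CCC(C)(C)CC2)c1-c1ccc2c(c1)CCN(Cc1ccc(F)cc1F)C2`: > 100%, a limit of the assay and not a number
- compound 3 `Cc1nc(C)c([C@H](OC(C)(C)C)C(=O)O)c(N2CCC(C)(C)CC2)c1-c1ccc2c(c1)CCN(c1ncnc3c1cnn3C)C2`: 95%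

Compound 3 at 95% holds the higher of the two plain numbers. The gap to the other plain number reads a number 31 percentage points higher from compound 1 to compound 3 (beyond the scatter). Against the limit of compound 2, the step reads a number at least 5 percentage points lower from compound 2 to compound 3 (that floor lies within the scatter).

Compound 4 `Cc1nc(C)c([C@H](OC(C)(C)C)C(=O)O)c(N2CCC(C)(C)CC2)c1-c1ccc2c(c1)CCN(c1nc3cnccc3s1)C2` is not yet measured. Its change is a group of 9 heavy atoms (6 carbon, 2 nitrogen, 1 sulfur; one five-membered aromatic ring with 2 hetero atoms, one six-membered aromatic ring with 1 hetero atom) in place of a group of 10 heavy atoms (6 carbon, 4 nitrogen; one five-membered aromatic ring with 2 hetero atoms, one six-membered aromatic ring with 2 hetero atoms), on an amine nitrogen in a ring. This exchange falls on an amine nitrogen in a ring, the same place that varies across the three measured compounds.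

Among the measured compounds shown here, three steps bear on it, and all three act at that place. Large steps appear in a number at least 36 percentage points higher from compound 1 to compound 2 (beyond the scatter) and in a number 31 percentage points higher from compound 1 to compound 3 (beyond the scatter), so this place can move the read-out substantially. However, no measured step exchanges one group with a five-membered and a six-membered aromatic ring for another such group. Direction therefore remains open, with only a slight lean downward, since compound 3 at 95% already sits high. No step beyond the scatter is expected, though the uncertainty is wide: a number 10 percentage points lower from compound 3 to compound 4 (within the scatter) is the expected change.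

Compound 4 is estimated at 85%, with an expected range from 55% to 110%.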

Compound 4, oral bioavailability: > 100%
Compound 4: a limit, no number; the forecaster's own chance of this, stated with the estimate: 15%; middle value at least 15 percentage points away from the limit.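

In this assay compound 4 gives > 100%, a limit of the assay and not a number. Swapping the group with four nitrogens for the sulfur-bearing group, also with one five-membered and one six-membered aromatic ring, on an amine nitrogen in a ring gives a number at least 5 percentage points higher from compound 3 to compound 4 (that floor lies within the scatter), so this exchange is not shown to change oral bioavailability, while the sulfur-bearing group also gives a number at least 36 percentage points higher from compound 1 to compound 4 (beyond the scatter), the same direction as the earlier steps away from compound 1. The step between compound 2 and compound 4 cannot be read, and the top of the series stays unranked: the limit of > 100% in this assay, at which 2 of the 4 values shown sit.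

The compounds shown do not tell which atoms of the entering group matter, nor whether sulfur or the ring nitrogens play any part in the read-out. As far as these compounds go, whether a much smaller group on this nitrogen, such as a plain methyl or an acetyl, or a group carrying a basic amine, keeps oral bioavailability at this level also stays open.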